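Hydrogen in place of methyl on an aromatic carbon

The source may hold more compounds than are shown below. What is called first, only, known or untested is meant among the compounds shown, and "the series" means these compounds.

In a functional assay on MDA-MB-231 cells (Homo sapiens) for antiproliferative activity, read by MTT assay (on this read-out higher numbers stand for weaker inhibition and lower numbers for stronger inhibition), compound 1 `CCCC/C=C\CCCCCCCCCC1(O)CC(=O)c2c(O)cc(OCOC)cc2O1` gives 42800 nM, and compound 2 `CC/C=C\C/C=C\C/C=C\CCCCCCCc1cc(=O)c2c(O)cc(OCOC)c(C)c2o1` gives 6790 nM, the lower of the two numbers by a gap beyond the scatter. Compound 3 `CC/C=C\C/C=C\C/C=C\CCCCCCCc1cc(=O)c2c(O)cc(OCOC)cc2o1` has not yet been measured. Its structure differs from that of compound 2 as follows: hydrogen in place of methyl on an aromatic carbon. Within the data shown here, no measured pair shows this change on its own, so no step beyond the scatter is expected in this assay. The expected change is a 1.3-fold higher number from compound 2 to compound 3 (0.12 log units; within the scatter), slightly towards weaker inhibition. The estimate for compound 3 is 9000 nM, with an expected range from 3500 nM to 23000 nM.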

Compound 3, half-maximal inhibitory concentration: 6790 nM
For compound 3 the middle estimate is 1.3-fold (0.12 log units) above the measured one; the measured number falls inside the stated range.
By their numbers in this assay, from the lowest: compounds 2 and 3 (each within the scatter of the next); then compound 1.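

Hydrogen in place of methyl on this aromatic carbon, ortho to a fused ring and to the methoxymethoxy group, gives in this assay no change at the digits printed from compound 2 to compound 3 (within the scatter). The methyl is therefore not needed at this position to hold the number of compound 2 in this read-out. Nothing on hand gives a reason for this result.

On these data alone, whether an amine or a carboxylic acid on this carbon would leave the number unchanged remains open. So does whether the same change would read alike with a longer chain on the shared core.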